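This account rests on a few compounds, and the source may have more. Where it says the series, first, only, none or still open, it means among the compounds named here.

Measured so far:
- compound 1 `CCN(CC)C(=O)Cn1c(-c2ccc(OC)cc2)cc2c(C)cc(C)cc21` gives 114 nM in an assay on membranes from HEK293 cells for displacement of a labelled ligand from Translocator protein (Homo sapiens), read by scintillation counting, with a stated time of 90 min; a higher number here means a weaker inhibitor, a lower number a stronger inhibitor
- compound 2 `CC(=O)N(Cc1ccc(OCCF)cc1)c1cc(C)cc(C)c1` gives 275 nM in this assay

Compound 2 has the higher of the two numbers, so it is the weaker inhibitor here; compound 1 gives the lower number, and that gap lies beyond the usual scatter. Compound 3 `CC(=O)N(Cc1ccc(OCc2ccccc2)cc1)c1cc(C)cc(C)c1` differs from compound 2 by phenyl in place of fluoromethyl on a saturated chain carbon bound to an oxygen on an aromatic ring. For the measured compounds named here, no measured pair shows this kind of change, so the direction is open; a step no larger than the usual scatter is expected. The estimate for compound 3 is 220 nM, with a range from 70 nM to 700 nM. That estimate means an expected step of a 1.3-fold lower number from compound 2 to compound 3 (0.10 log units; within the scatter).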

Compound 3, inhibition constant: 377 nM
Compound 3: middle estimate off by 1.7-fold (0.23 log units), on the low side; the range from low to high includes it.
By their numbers in this assay, from the lowest: compound 1; then compounds 2 and 3 (each within the scatter of the next).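

Swapping fluoromethyl for phenyl on the saturated chain carbon bound to an oxygen on an aromatic ring gives a 1.4-fold higher number from compound 2 to compound 3 (0.14 log units; within the scatter) in this assay, so the two cannot be told apart. This place therefore accepts an added aromatic ring of six carbons without a change beyond the scatter. No measurement shown explains this result.

Going by these compounds, whether an amine or a carboxylic acid at the end of this chain would fare the same remains open. So does the effect of a longer chain between the oxygen and the phenyl.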